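This account rests on a few compounds, and the source may have more. Where it says the series, first, only, none or still open, it means among the compounds named here.

Compound 1 `O=C(Nc1ccc(-n2ccc3c(NC(=O)c4ccccc4)ncnc32)cc1)c1ccc(Cl)c(Cl)c1`: 2000 nM
Compound 2 `CC(=O)Nc1ncnc2c1ccn2-c1ccc(NC(=O)Nc2ccc(Cl)c(C(F)(F)F)c2)cc1`: > 10000 nM
Compound 3 `O=C(Nc1ccc(-n2ccc3c(NC(=O)c4ccccc4)ncnc32)cc1)Nc1ccc(Cl)c(C(F)(F)F)c1`: 4600 nM

All three were measured in a functional assay on A375P cells (Homo sapiens) for antiproliferative activity, read by MTT assay, with a stated time of 24 h; a higher number here means a weaker inhibitor, a lower number a stronger inhibitor. Compound 1 gives 2000 nM, and compound 3 gives 4600 nM. Compound 2 gives only a limit, > 10000 nM.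

Among the numbers shown, compound 1 stands at the lowest; compound 3 comes nearest, and the move between them is a 2.3-fold higher number from compound 1 to compound 3 (0.36 log units; beyond the scatter). Compound 4 `O=C(Nc1ccc(-n2ccc3c(NC(=O)c4ccccc4)ncnc32)cc1)c1ccc(Cl)c(C(F)(F)F)c1` differs from compound 1 in one place: trifluoromethyl in place of chloro on an aromatic carbon.

Within the data shown here, of the measured steps, only the step from compound 1 to compound 3 touches this exchange, and it carries a second alteration on a carbonyl carbon at the same time, so it cannot be read alone. The step from compound 2 to compound 3, an at least 2.1-fold lower number from compound 2 to compound 3 (0.33 log units; beyond the scatter), concerns a group on the other carbonyl carbon and says nothing about chloro against trifluoromethyl. In this assay a small step is therefore expected, in either direction or none beyond the scatter. Compound 4 is expected to give about 2500 nM, between 1000 nM and 6500 nM. The expected step is a 1.3-fold higher number from compound 1 to compound 4 (0.10 log units; within the scatter).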

Compound 4, half-maximal inhibitory concentration: 2300 nM
Beside the measured number, compound 4's estimate is 1.1-fold (0.04 log units) above it, and the stated range covers the measured number.
By their numbers in this assay, from the lowest: compounds 1, 4 and 3 (each within the scatter of the next, the first and the last beyond it). At a limit, above all of these: compound 2.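

In this assay, the exchange of chloro for trifluoromethyl can now be read alone, on an aromatic carbon ortho to a chloro group, and it gives a 1.2-fold higher number from compound 1 to compound 4 (0.06 log units; within the scatter). Removing the amino link on the carbonyl carbon gives a 2.0-fold lower number from compound 3 to compound 4 (0.30 log units; within the scatter), so neither single change steps beyond the scatter, although compound 1 and compound 3, which differ by both, stand beyond it. Nothing measured here accounts for either step.

Chloro and trifluoromethyl are the only groups shown at this position, so what a nitrile, a methoxy group or an amine would do there stays open. Also open, on these data alone, is how compound 4 would respond if the phenyl on its other carbonyl carbon gave way to a longer chain.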